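This account rests on a few compounds, and the source may have more. Where it says the series, first, only, none or still open, it means among the compounds named here.

Working notes on the series. Among the measured compounds shown here, compound 3 `CCOC(=O)c1c(-c2ccc(Cl)cc2)cc(-c2ccccc2)nc1Nc1ccccc1` in a functional assay on the whole organism (strain Wister albino) for inhibition, with Rattus norvegicus as the target, read by paw edema, with a stated time of 1 h, at a dose of 50 mg/kg by the intraperitoneal route (a higher number here means more inhibition at the dose given (going by the name of the read-out), a lower number less inhibition), gives 62.3%, the largest of the three values so far, though the gaps to the others lie within the scatter: compound 1 `CCOC(=O)c1c(-c2ccc(Cl)cc2)cc(-c2ccccc2)nc1N1CCCCC1` gives 59.3% in this assay, and compound 2 `CCOC(=O)c1c(-c2ccc(Cl)c(Cl)c2)cc(-c2ccccc2)nc1N1CCCCC1` gives 53.5%. The two single-point steps measured so far, a number 5.8 percentage points lower from compound 1 to compound 2 (within the scatter) and a number 3 percentage points higher from compound 1 to compound 3 (within the scatter), both stay within the scatter.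

Compound 4 `CCOC(=O)c1c(-c2ccc(Cl)cc2)cc(-c2ccccc2)nc1Nc1ccc(OC)cc1` differs from compound 3 by methoxy in place of hydrogen on an aromatic carbon. For the measured compounds named here, no measured step adds a methoxy; the nearest comparison is the addition of a chloro to an aromatic carbon, which gave a number 5.8 percentage points lower from compound 1 to compound 2 (within the scatter), and the exchange of piperidin-1-yl for anilino, which gave a number 3 percentage points higher from compound 1 to compound 3 (within the scatter). Both were within the scatter, so no step beyond the scatter is expected in this assay for this change either.

Compound 4 is therefore expected to give about 62% in this assay, with a range of 50% to 74%. The expected step is a number 0.3 percentage points lower from compound 3 to compound 4 (within the scatter), within the scatter.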

Compound 4, a percentage reported as inhibition, in the whole organism at one dose (the size of the read-out at that dose, not a potency): 33.3%
Compound 4: the middle estimate sits 28.7 percentage points above what was measured, outside the stated range (below it).
By their numbers in this assay, from the lowest: compound 4; then compounds 2, 1 and 3 (each within the scatter of the next).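

In this assay, among the compounds shown here, methoxy in place of hydrogen on the anilino ring, para to a large group, gives a number 29 percentage points lower from compound 3 to compound 4 (beyond the scatter) and is the first step beyond the scatter. This place is therefore not indifferent to substitution, even though the anilino group itself was accepted, with a number 3 percentage points higher from compound 1 to compound 3 (within the scatter) in place of piperidin-1-yl. The same exchange made with (4-methoxyphenyl)amino gives a number 26 percentage points lower from compound 1 to compound 4 (beyond the scatter) and so does not carry over the neutral result seen for anilino. Nothing at hand explains this loss.

The compounds shown leave open whether the loss belongs to methoxy alone or would also follow a hydroxyl, methyl or chloro group at the same place. On these data alone, how a longer alkoxy chain there would read in this assay also remains open.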